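Swapping a Halogenated Phenyl Ring on a Shared Core

The compounds below may be only part of what the source reports. "The series", "measured", "known", "first", "only" and "open" are said of these compounds alone.

Compound 1 `CCNC(=O)c1cc(Oc2ccc(NC(=O)c3cc4cccnc4n(-c4ccccc4F)c3=O)cc2)ccn1`, compound 2 `CCNC(=O)c1cc(Oc2ccc(NC(=O)c3cc4cccnc4n(-c4ccc(F)cc4)c3=O)cc2)ccn1` and compound 3 `CCNC(=O)c1cc(Oc2ccc(NC(=O)c3cc4cccnc4n(-c4ccc(Br)cc4F)c3=O)cc2)ccn1` share one core and differ only in the halogenated phenyl ring carried on an aromatic nitrogen. In a functional assay on HT-29 cells (Homo sapiens) for antiproliferative activity, read by MTT assay, with a stated time of 72 h (a lower number here means a stronger inhibitor, a higher number a weaker inhibitor), compound 1 gives 260 nM, compound 2 gives 190 nM and compound 3 gives 2070 nM, the highest number of the three. Compound 4 `CCNC(=O)c1cc(Oc2ccc(NC(=O)c3cc4cccnc4n(-c4ccc(F)c(Cl)c4)c3=O)cc2)ccn1` carries 3-chloro-4-fluorophenyl in place of 4-bromo-2-fluorophenyl on an aromatic nitrogen. Going by the values given here, two measured steps bear on this: an 8.0-fold higher number from compound 1 to compound 3 (0.90 log units; beyond the scatter), and an 11-fold higher number from compound 2 to compound 3 (1.04 log units; beyond the scatter), both beyond the scatter. Because the ring without bromine in compound 2 gives 190 nM, removing bromine is expected to lower the number, though the added chlorine leaves the outcome uncertain. Compound 4 is therefore estimated at 600 nM, with a range from 150 nM to 2500 nM. That estimate amounts to a 3.5-fold lower number from compound 3 to compound 4 (0.54 log units; beyond the scatter).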

Compound 4, half-maximal inhibitory concentration: 2600 nM
The estimate for compound 4 lay 4.3-fold (0.64 log units) below the measured number, outside the stated range (above it).
By their numbers in this assay, from the lowest: compounds 2 and 1 (each within the scatter of the next); then compounds 3 and 4 (each within the scatter of the next).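

In this assay the 4-bromo-2-fluorophenyl and 3-chloro-4-fluorophenyl rings cannot be told apart, with a 1.3-fold higher number from compound 3 to compound 4 (0.10 log units; within the scatter) as their step, so a high number at this position does not require bromine. Chlorine on the ring of compound 2 is enough for a large step, a 14-fold higher number from compound 2 to compound 4 (1.14 log units; beyond the scatter), and the ring of compound 1 gives a similar contrast, a 10-fold higher number from compound 1 to compound 4 (1.00 log units; beyond the scatter). Nothing measured here explains these steps. Open still is whether a ring carrying chlorine without fluorine behaves the same way, and how a methoxy group or an amine on this ring would fare.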